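Adding trifluoromethyl to the benzyl group of compound 3

This account rests on a few compounds, and the source may have more. Where it says the series, first, only, none or still open, it means among the compounds named here.

In a functional assay on MCF7 cells (Homo sapiens) for antiproliferative activity, read by MTT assay, with a stated time of 72 h (a higher number here means a weaker inhibitor, a lower number a stronger inhibitor), compound 3 `c1ccc(COc2ccc(Nc3ncnc4cc5c(cc34)OCCOCCOCCO5)cc2)cc1` gives 8340 nM, the lower of the two actual numbers in the series. Compound 2 `O=[N+]([O-])c1ccc(COc2ccc(Nc3ncnc4cc5c(cc34)OCCOCCO5)cc2)cc1` gives 39700 nM. The gap between these two compounds lies beyond the scatter. Compound 1 `c1ccc(COc2ccccc2Nc2ncnc3cc4c(cc23)OCCOCCO4)cc1` returns only a limit, > 100000 nM. Compound 4 `FC(F)(F)c1ccc(COc2ccc(Nc3ncnc4cc5c(cc34)OCCOCCOCCO5)cc2)cc1` differs from compound 3 by trifluoromethyl in place of hydrogen on an aromatic carbon, para to a large group (trifluoromethyl in place of hydrogen on an aromatic carbon). Going by the values given here, no measured pair isolates this change, so the expectation is loose: a modest step toward a higher number in this assay, perhaps none beyond the scatter. The estimated change is a 1.4-fold higher number from compound 3 to compound 4 (0.16 log units; within the scatter). For compound 4 the expected value is 12000 nM, with an estimated range of 3500 nM to 45000 nM.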

Compound 4, half-maximal inhibitory concentration: 28500 nM
The estimate for compound 4 lay 2.4-fold (0.38 log units) below the measured number; the range from low to high includes it.
By their numbers in this assay, from the lowest: compound 3; then compounds 4 and 2 (each within the scatter of the next). At a limit, above all of these: compound 1.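

Going by these compounds alone, this is the first change read at a single place: in this assay, benzyl to 4-(trifluoromethyl)benzyl gives a 3.4-fold higher number from compound 3 to compound 4 (0.53 log units; beyond the scatter) on an aromatic carbon para to a large group. The position therefore responds to substitution, and trifluoromethyl here raises the number rather than leaving it unchanged. Nothing available accounts for this step.

One substituent cannot show whether any group at this place raises the number or only trifluoromethyl does. A methoxy group, an amine or a carboxylic acid at the same carbon would separate those readings.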